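This account rests on a few compounds, and the source may have more. Where it says the series, first, only, none or still open, it means among the compounds named here.

Among the measured compounds shown here, compound 3 `Cc1cc(Nc2nc(NCc3ccc(Br)cc3)nc3[nH]ncc23)n[nH]1` stands at the highest of the three numbers so far in an assay on isolated protein for inhibition of serine/threonine-protein kinase PAK 4 (Homo sapiens), read by HTRF, with a stated time of 60 min (a lower number here means a stronger inhibitor, a higher number a weaker inhibitor), giving 1320 nM. Compound 1 `Cc1cc(Nc2nc(NCc3ccccc3Br)nc3[nH]ncc23)n[nH]1` gives 1090 nM, and compound 2 `Cc1cc(Nc2nc(NCc3cccc(Cl)c3)nc3[nH]ncc23)n[nH]1` gives 611 nM. The step of a 2.2-fold higher number from compound 2 to compound 3 (0.33 log units; beyond the scatter) is modest, while the steps of a 1.8-fold lower number from compound 1 to compound 2 (0.25 log units; within the scatter) and a 1.2-fold higher number from compound 1 to compound 3 (0.08 log units; within the scatter) stay within the scatter. Compound 4 `Cc1cc(Nc2nc(NCc3ccc(F)cc3F)nc3[nH]ncc23)n[nH]1` differs from compound 3 by 2,4-difluorophenyl in place of 4-bromophenyl on a saturated chain carbon bound to a nitrogen on an aromatic ring. All three measured steps bear on this change, since each swaps one halogenated phenyl for another at the same place, and none exceeded a modest size. A small step is therefore expected in this assay, likely within the scatter, with a slight lowering if anything. Compound 4 is expected to give about 900 nM in this assay, within a range from 350 nM to 2500 nM. This expected step amounts to a 1.5-fold lower number from compound 3 to compound 4 (0.17 log units; within the scatter).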

Compound 4, half-maximal inhibitory concentration: 96.1 nM
Compound 4: the middle estimate sits 9.4-fold (0.97 log units) above what was measured, outside the stated range (below it).
By their numbers in this assay, from the lowest: compound 4; then compounds 2, 1 and 3 (each within the scatter of the next, the first and the last beyond it).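

In this assay the phenyl group on a saturated chain carbon bound to a nitrogen on an aromatic ring turns out to matter far more than the earlier halogen swaps suggested, with a 14-fold lower number from compound 3 to compound 4 (1.14 log units; beyond the scatter) and an 11-fold lower number from compound 1 to compound 4 (1.05 log units; beyond the scatter) and also a 6.4-fold lower number from compound 2 to compound 4 (0.80 log units; beyond the scatter) in this series. Compound 4 is the only one here carrying two halogens on that phenyl, and the only one carrying fluorine. No measurement shown here explains the gain. The compounds leave open whether fluorine itself or the presence of two halogens accounts for it. From the compounds shown here alone, how a phenyl with one fluorine, a methoxyphenyl or a pyridine ring would read at this place also remains open.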